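The source may report more compounds than this note shows. Statements on the series, on what has been measured and on what is new or still open speak of the compounds shown alone.

Compound 1 `COc1ccc(/C=C(\C#N)C(=O)N/N=C(\C)c2c(O)c3ccc(O)cc3oc2=O)cc1OC` carries a 3,4-dimethoxyphenyl on a double-bonded chain carbon bound to a double-bonded chain carbon. For the measured compounds named here, in a functional assay on SK-N-SH cells (Homo sapiens) for cytotoxicity, read by MTT assay, with a stated time of 24 h (a higher number here means a weaker inhibitor, a lower number a stronger inhibitor), compound 1 gives 21500 nM, the highest of the two numbers measured so far. Compound 2 `C/C(=N\NC(=O)/C(C#N)=C/c1ccc([N+](=O)[O-])cc1)c1c(O)c2ccc(O)cc2oc1=O` gives 10300 nM, a change of a 2.1-fold lower number from compound 1 to compound 2 (0.32 log units; beyond the scatter). Compound 3 `C/C(=N\NC(=O)/C(C#N)=C/c1ccccc1[N+](=O)[O-])c1c(O)c2ccc(O)cc2oc1=O` differs from compound 1 by 2-nitrophenyl in place of 3,4-dimethoxyphenyl on a double-bonded chain carbon bound to a double-bonded chain carbon. Going by the values given here, the only step that bears on this change is the one that brought in 4-nitrophenyl, so a lowering of similar or somewhat smaller size is expected, a 1.7-fold lower number from compound 1 to compound 3 (0.22 log units; within the scatter). Compound 3 is therefore estimated at 13000 nM, within 6000 nM to 30000 nM.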

Compound 3, half-maximal inhibitory concentration: 12300 nM
Beside the measured number, compound 3's estimate is 1.1-fold (0.02 log units) above it, and the stated range covers the measured number.
By their numbers in this assay, from the lowest: compounds 2, 3 and 1 (each within the scatter of the next, the first and the last beyond it).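

In this assay the 2-nitrophenyl group gives a 1.7-fold lower number from compound 1 to compound 3 (0.24 log units; within the scatter) and so, unlike 4-nitrophenyl, does not separate from 3,4-dimethoxyphenyl at this place. The two nitrophenyl groups give a 1.2-fold higher number from compound 2 to compound 3 (0.08 log units; within the scatter) and cannot be told apart here, so the nitro group's place on the ring shows no readable effect in these compounds. Nothing measured here explains these numbers. The compounds shown leave open whether a phenyl carrying an amine or a carboxylic acid instead of the nitro group would give a number beyond the scatter of these three.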